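The compounds below may be only part of what the source reports. "The series", "measured", "known", "first", "only" and "open" are said of these compounds alone.

Measured in an ADME assay on microsomes from liver (Canis lupus familiaris) for metabolic stability, read by LC-MS, using NADPH, with a stated time of 10 min, tested at 0.1 uM; on this read-out lower numbers stand for slow clearance and higher numbers for fast clearance:
compound 1 `COc1ccc(F)cc1N1C(=O)CSC1c1cccc(C(=O)NCCCCn2cccn2)c1` — 480 mL.min-1.g-1
compound 2 `C#Cc1cccc(N2C(=O)CSC2c2cccc(C(=O)NCCCCc3ccccc3)c2)c1` — 973 mL.min-1.g-1
compound 3 `O=C(NCCCCc1ccccc1)c1cccc(C2SCC(=O)N2c2ccc(C3CC3)cc2)c1` — 1080 mL.min-1.g-1

Compound 3 stands at the highest number of the three in this assay; against compound 2 the gap is within the scatter, while compound 1 lies beyond it at a lower number. Going by the values given here, the one recorded step, a 1.1-fold higher number from compound 2 to compound 3 (0.05 log units; within the scatter), swapped the group on the ring nitrogen and stayed within the scatter. Compound 4 `COc1ccc(F)cc1N1C(=O)CSC1c1cccc(C(=O)NCCCCc2ccccc2)c1` is reached from compound 3 by 5-fluoro-2-methoxyphenyl in place of 4-cyclopropylphenyl on an amide-type nitrogen in a ring. Among the compounds with values here, no measured step covers this exact swap; compound 1 carries the entering group but also a different amide tail, so its lower number only hints at a modest drop. For compound 4 a step of a 1.7-fold lower number from compound 3 to compound 4 (0.22 log units; within the scatter) toward slower clearance is expected, leaning on compound 1 at 480 mL.min-1.g-1. The estimate for compound 4 is 650 mL.min-1.g-1, range 320 mL.min-1.g-1 to 1200 mL.min-1.g-1.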

Compound 4, intrinsic clearance in microsomes: 1650 mL.min-1.g-1
Compound 4: middle estimate off by 2.5-fold (0.40 log units), on the low side; the whole stated range lies below it.
By their numbers in this assay, from the lowest: compound 1; then compounds 2, 3 and 4 (each within the scatter of the next).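

On the amide-type nitrogen in a ring, the three groups carried with the phenyl tail stay within the scatter in this assay, with a 1.5-fold higher number from compound 3 to compound 4 (0.18 log units; within the scatter) and a 1.7-fold higher number from compound 2 to compound 4 (0.23 log units; within the scatter) adding 5-fluoro-2-methoxyphenyl to that set. Going by these compounds alone, with 5-fluoro-2-methoxyphenyl held fixed, the change at the end of the chain gives a 3.4-fold higher number from compound 1 to compound 4 (0.54 log units; beyond the scatter) and is the only single change here beyond the scatter, with phenyl in place of 1H-pyrazol-1-yl. No measured evidence accounts for either result.

Open, from the compounds shown here alone, is whether 1H-pyrazol-1-yl gives a similar step alongside 4-cyclopropylphenyl or 3-ethynylphenyl. Also open, going by these compounds, is how a chain ending in an amine or a carboxylic acid would read.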